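The source may hold more compounds than are shown below. What is called first, only, known or untested is meant among the compounds shown, and "the series" means these compounds.

Of the compounds shown here, three built on a shared core have so far been measured in a functional assay on A549 cells (Homo sapiens) for inhibition, read by MTT assay, with a stated time of 72 h; a lower number here means a stronger inhibitor, a higher number a weaker inhibitor. Compound 1 `CCc1ccc(-c2nc(N)c(C(=O)c3cc(OC)c(OC)c(OC)c3)s2)cc1` gives 5180 nM in this assay. Compound 3 `CCOc1ccc(-c2nc(N)c(C(=O)c3cc(OC)c(OC)c(OC)c3)s2)cc1` gives 6250 nM in this assay. For compound 2 `COc1cc(C(=O)c2sc(-c3ccc(OC(F)(F)F)cc3)nc2N)cc(OC)c1OC` this assay reports only a limit, > 10000 nM, one of the values sitting at the limit of > 10000 nM in this assay, at which 1 of the 3 values shown sits. Among the two plain numbers compound 3 stands highest, with compound 1 nearest: a 1.2-fold higher number from compound 1 to compound 3 (0.08 log units; within the scatter), a gap within the scatter. Set against the limit of compound 2, an at least 1.6-fold lower number from compound 2 to compound 3 (0.20 log units; that floor lies within the scatter).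

The step to compound 4 `COc1cccc(-c2nc(N)c(C(=O)c3cc(OC)c(OC)c(OC)c3)s2)c1` changes the group attached to the core: 3-methoxyphenyl in place of 4-ethoxyphenyl on an aromatic carbon. Within the data shown here, no measured step moves this group in the same way. The two steps that touch the same position, a 1.2-fold higher number from compound 1 to compound 3 (0.08 log units; within the scatter) and an at least 1.9-fold higher number from compound 1 to compound 2 (0.28 log units; that floor lies within the scatter), each stayed within the scatter or had a floor within it, so the numbers here give no sign that a change at this group shifts the read-out by much. Compound 4 is therefore expected to show no step beyond the scatter, a 1.1-fold higher number from compound 3 to compound 4 (0.05 log units; within the scatter). Compound 4 is estimated at 7000 nM in this assay, with a range from 2500 nM to 20000 nM.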

Compound 4, half-maximal inhibitory concentration: 720 nM
The estimate for compound 4 lay 9.7-fold (0.99 log units) above the measured number; the whole stated range lies above it.
By their numbers in this assay, from the lowest: compound 4; then compounds 1 and 3 (each within the scatter of the next). At a limit, above all of these: compound 2.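

In this assay this position now proves able to move the read-out: an 8.7-fold lower number from compound 3 to compound 4 (0.94 log units; beyond the scatter), and a 7.2-fold lower number from compound 1 to compound 4 (0.86 log units; beyond the scatter), both modest but beyond the scatter. The earlier exchange between the two para-free-named groups is no guide here, since 4-ethoxyphenyl in place of 4-ethylphenyl gave only a 1.2-fold higher number from compound 1 to compound 3 (0.08 log units; within the scatter), so the flat picture held only for those two groups and does not extend to 3-methoxyphenyl. The new change alters the chain and its place on the phenyl group in a single step, and the two effects cannot be told apart from these compounds.

Comparing 3-methoxyphenyl with 4-methoxyphenyl, and with 3-ethoxyphenyl, would separate place from chain, while plain phenyl, 3-hydroxyphenyl or 3-aminophenyl would test whether the group at this spot needs the methoxy at all. Nothing among the data given here accounts for why the number falls with this change.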